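This account rests on a few compounds, and the source may have more. Where it says the series, first, only, none or still open, it means among the compounds named here.

In a functional assay on COR-L23 cells (Homo sapiens) for antiproliferative activity, read by CellTiter-Glo, with a stated time of 72 h (a lower number here means a stronger inhibitor, a higher number a weaker inhibitor), compound 1 `O=C(Nc1ccc(CN2Cc3ccccc3C2=O)cc1)N1CC(c2cccnc2)C1` gives 9.9 nM and compound 2 `C[C@H](NC(=O)c1cccc(F)c1)c1ccc(NC(=O)N2CC(c3cccnc3)C2)cc1` gives 10 nM as its value, two numbers within the usual scatter of each other. Compound 3 `C[C@H](NC(=O)c1cccc(F)c1)c1ccc(NC(=O)N2CC(c3ccc(N)nc3)C2)cc1` gives 27 nM and so has the highest number of the three, which makes it the weakest inhibitor measured so far. Within the data shown here, putting amino in place of hydrogen on an aromatic carbon gives a 2.7-fold higher number from compound 2 to compound 3 (0.43 log units; beyond the scatter) and this modest step is the only one measured between compounds differing in one place.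

Compound 4 `CCC(=O)N[C@@H](C)c1ccc(NC(=O)N2CC(c3ccc(N)nc3)C2)cc1` keeps that amino group and carries ethyl in place of 3-fluorophenyl on a carbonyl carbon. Among the measured compounds shown here, no measured step shows this exchange, so the earlier step offers only a sense of scale and not a direct precedent. Removing a whole ring is a larger structural change than adding one amino group, so a somewhat larger step than a 2.7-fold higher number from compound 2 to compound 3 (0.43 log units; beyond the scatter) is expected, with real uncertainty about its size. The expected change is a 2.2-fold higher number from compound 3 to compound 4 (0.35 log units; beyond the scatter) and this estimate points to a weaker inhibitor, although a result close to compound 3 would not be surprising. In this assay the estimated value for compound 4 is 60 nM within an expected range of 15 nM to 240 nM.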

Compound 4, half-maximal inhibitory concentration: 120 nM
Compound 4: middle estimate off by 2.0-fold (0.30 log units), on the low side, and the stated range covers the measured number.
By their numbers in this assay, from the lowest: compounds 1 and 2 (each within the scatter of the next); then compound 3; then compound 4.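

Among these compounds, on a carbonyl carbon whose other neighbour is an amide-type nitrogen, ethyl in place of 3-fluorophenyl gives a 4.4-fold higher number from compound 3 to compound 4 (0.65 log units; beyond the scatter) in this assay, so this is the first measured evidence that the group at this position matters: the aromatic ring can be exchanged for a short chain only at a real cost in potency. Among the compounds shown here, this exchange removes the ring and its fluorine together, and it has so far been seen only in compounds that carry the amino group, where the earlier change on the other side of the molecule gave a 2.7-fold higher number from compound 2 to compound 3 (0.43 log units; beyond the scatter). Nothing measured here explains why the smaller ethyl group gives the weaker inhibitor.

Going by these compounds, what remains open is whether the loss follows the ring or the fluorine, which plain phenyl on the same carbonyl carbon would help to separate, and whether a longer chain such as hexyl would recover any of the lost potency. On these data alone, it is also open whether the same exchange would cost as much in a compound without the amino group, such as compound 2.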